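Ketone aryl swap in the aminothiazole series: thiophene variant

The compounds below may be only part of what the source reports. "The series", "measured", "known", "first", "only" and "open" are said of these compounds alone.

Measured compounds:
- compound 1 `COc1cccc(Nc2ncc(C(=O)c3ccccc3F)s2)c1`: 1000 nM
- compound 2 `Cc1ccccc1C(=O)c1cnc(Nc2cccc(C(F)(F)F)c2)s1`: 63 nM
- compound 3 `O=C(c1cnc(Nc2cccc(C(F)(F)F)c2)s1)c1ccccc1C(F)(F)F`: 138 nM

In an assay for inhibition of Neuropeptide Y receptor type 5 (Mus musculus) (a lower number here means a stronger inhibitor, a higher number a weaker inhibitor), compound 2 gives the lowest number of the three measured compounds. Its nearest neighbour is compound 3, with the step of a 2.2-fold higher number from compound 2 to compound 3 (0.34 log units; beyond the scatter); compound 1 lies furthest away, differing from compound 2 in two places and giving a weaker result.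

Compound 4 `Cc1cc(C(=O)c2cnc(Nc3cccc(C(F)(F)F)c3)s2)c(C)s1` is not yet measured. The change from compound 2 is 2,5-dimethylthiophen-3-yl in place of 2-methylphenyl on a carbonyl carbon. Among the measured compounds shown here, no measured step bears directly on this exchange: the only single-place step in the set, the one from compound 2 to compound 3, concerns the substituent on the aromatic ring attached to the carbonyl and was modest in size. The aryl-to-thienyl exchange on the ketone is therefore uncharted here, and the expectation rests on compound 2 alone as the starting point.

For compound 4 the number in this assay is estimated at 100 nM, with a range from 30 nM to 320 nM. This estimate amounts to an expected step of a 1.6-fold higher number from compound 2 to compound 4 (0.20 log units; within the scatter), modest and uncertain in direction given the absence of a comparable measured step.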

Compound 4, half-maximal inhibitory concentration: 395 nM
The estimate for compound 4 lay 4.0-fold (0.60 log units) below the measured number; the measured number lies above the stated range.
By their numbers in this assay, from the lowest: compound 2; then compound 3; then compound 4; then compound 1.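

In this assay, this position responds to a change of the ring itself and not only of its substituent: 2,5-dimethylthiophen-3-yl in place of 2-methylphenyl on a carbonyl carbon gives a 6.3-fold higher number from compound 2 to compound 4 (0.80 log units; beyond the scatter), a larger step than a 2.2-fold higher number from compound 2 to compound 3 (0.34 log units; beyond the scatter). The leaving and entering groups hold the same number of heavy atoms, so that count alone does not track the number in this set. Nothing available explains the rise.

As far as these compounds go, whether the rise follows from the sulfur-containing ring or from its two methyl groups remains open, and a thiophen-3-yl without methyl groups on the carbonyl carbon would separate the two. Also open, from the compounds shown here alone, is how a pyridine ring at this place would compare with the 2-methylphenyl of compound 2.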